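The source may hold more compounds than are shown below. What is called first, only, known or untested is meant among the compounds shown, and "the series" means these compounds.

Compound 1 `COc1cccc(NC(=O)c2nnn(Cc3ccc([S+](C)[O-])cc3)c2N)c1`: 0.5 mL.min-1.g-1
Compound 2 `COc1cccc(NC(=O)c2nnn(Cc3ccccc3)c2N)c1`: 3.7 mL.min-1.g-1
Compound 3 `COc1cccc(NC(=O)c2nnn(Cc3ccc(SC)cc3)c2N)c1`: 6.4 mL.min-1.g-1

In an ADME assay on microsomes from liver (Mus musculus, strain CD1) for metabolic stability, read by HPLC, using NADPH, with a stated time of 30 min (on this read-out lower numbers stand for slow clearance and higher numbers for fast clearance), compound 3 stands at 6.4 mL.min-1.g-1. The step of a 1.7-fold higher number from compound 2 to compound 3 (0.24 log units; within the scatter) lies within the scatter, whereas the step of a 13-fold higher number from compound 1 to compound 3 (1.11 log units; beyond the scatter) is large. Compound 4 `COc1cccc(NC(=O)c2nnn(Cc3ccc(OC(F)(F)F)cc3)c2N)c1` carries trifluoromethoxy in place of methylsulfanyl on an aromatic carbon. Among the compounds with values here, no measured compound carries trifluoromethoxy, so the evidence is indirect. The step of a 7.4-fold higher number from compound 1 to compound 2 (0.87 log units; beyond the scatter) and the large step above both start from the group of compound 1, which neither compound 3 nor compound 4 carries. The closer guide is the small step of a 1.7-fold higher number from compound 2 to compound 3 (0.24 log units; within the scatter). No change beyond the scatter is therefore expected, and the estimated step is a 1.3-fold lower number from compound 3 to compound 4 (0.11 log units; within the scatter). Compound 4 is expected at 5 mL.min-1.g-1, with an estimated range of 2 mL.min-1.g-1 to 12 mL.min-1.g-1.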

Compound 4, intrinsic clearance in microsomes: 2.9 mL.min-1.g-1
For compound 4 the middle estimate is 1.7-fold (0.24 log units) above the measured one; the range from low to high includes it.
By their numbers in this assay, from the lowest: compound 1; then compounds 4, 2 and 3 (each within the scatter of the next, the first and the last beyond it).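

In this assay, within the data shown here, trifluoromethoxy and methylsulfanyl at this position are separated by a step beyond the scatter (a 2.2-fold lower number from compound 3 to compound 4 (0.34 log units; beyond the scatter)), the first such step here that does not involve the group of compound 1. Yet trifluoromethoxy stays within the scatter of hydrogen (a 1.3-fold lower number from compound 2 to compound 4 (0.11 log units; within the scatter)), as methylsulfanyl does. The group of compound 1 remains set apart from trifluoromethoxy as well (a 5.8-fold higher number from compound 1 to compound 4 (0.76 log units; beyond the scatter)), and nothing at hand explains these steps. Going by these compounds, whether methylsulfonyl, an amine or a carboxylic acid here would fall nearer compound 1 or compound 2 stays open.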